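The compounds below may be only part of what the source reports. "The series", "measured", "known", "first", "only" and "open" are said of these compounds alone.

Measured compounds:
Compound 1 `COc1ccccc1-c1ccc(S(=O)(=O)N2CCC(N3CCC(C)CC3)CC2)cc1` — > 5000 nM
Compound 2 `CC1CCN(C2CCN(S(=O)(=O)c3cccnc3F)CC2)CC1` — > 10000 nM

Two compounds have so far been examined in an ADME assay on HCT-116 cells (Homo sapiens) for cytotoxicity, read by CellTiter-Glo, with a stated time of 72 h; a lower number here means a stronger inhibitor, a higher number a weaker inhibitor. Compound 1 `COc1ccccc1-c1ccc(S(=O)(=O)N2CCC(N3CCC(C)CC3)CC2)cc1` gives in this assay a value of > 5000 nM, which is a limit of the assay rather than a measured number. Compound 2 `CC1CCN(C2CCN(S(=O)(=O)c3cccnc3F)CC2)CC1` gives in this assay a value of > 10000 nM, again only a limit and not a number. Where compound 2 stands is thus known only as a boundary: its value sits at the limit of > 10000 nM in this assay, at which 1 of the 2 values shown sits. Within the data shown here, no step between two measured compounds is available, so nothing is known here about how large a change in structure shifts the read-out.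

Compound 3 `CC1CCN(C2CCN(S(=O)(=O)c3cncc(Br)c3)CC2)CC1` has not yet been measured in this assay. It differs from compound 2 in a single place: 5-bromopyridin-3-yl in place of 2-fluoropyridin-3-yl on a sulfonyl sulfur. With compound 2 at a limit, no direction can be read from the numbers, and no step beyond the usual scatter is anticipated in this assay. Compound 3 is expected to give about 15000 nM, within a range from 5000 nM to 50000 nM, most likely reported again only as a limit. The expected step is a step that the limit leaves unreadable from compound 2 to compound 3.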

Compound 3, half-maximal inhibitory concentration: > 10000 nM
Compound 3 was reported as a limit; the forecaster's own chance of this, stated with the estimate: 80%; the middle value is on the limit's open side.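

Compound 2 and compound 3 are both reported only as limits in this assay, and no step between them can be read: the limit of > 10000 nM in this assay, at which 2 of the 3 values shown sit.

The compounds shown leave open whether 5-bromopyridin-3-yl and 2-fluoropyridin-3-yl on a sulfonyl sulfur differ at all in this assay, and what actual value, if any, either compound would reach.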